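Shortening the Alkyl Chain of a Sulfonyl Hydrate

This account rests on a few compounds, and the source may have more. Where it says the series, first, only, none or still open, it means among the compounds named here.

Among the compounds with values here, compound 2 `CCCCCCCCCCCCS(=O)(=O)CC(O)(O)C(F)(F)F` gives the lowest of the two numbers measured so far in an assay on isolated protein for inhibition of liver carboxylesterase 1 (Homo sapiens), with a stated time of 5 min (a higher number here means a weaker inhibitor, a lower number a stronger inhibitor), with 741 nM. Within the data shown here, compound 1 `CCCCCC[S+]([O-])CC(O)(O)C(F)(F)F`, the only other measured compound, gives 79400 nM in this assay, a value beyond the scatter above that of compound 2. Compound 3 `CCCCCCCCCCS(=O)(=O)CC(O)(O)C(F)(F)F` differs from compound 2 by hydrogen in place of ethyl on a saturated chain carbon, ten or more bonds along the chain from a sulfonyl sulfur. Among the measured compounds shown here, no step between measured compounds covers this change; a modest rise in this assay, slightly beyond the scatter, is expected. The expected step is a 2.2-fold higher number from compound 2 to compound 3 (0.33 log units; beyond the scatter). Compound 3 is therefore estimated at 1600 nM, with a range from 600 nM to 4500 nM.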

Compound 3, inhibition constant: 794 nM
Beside the measured number, compound 3's estimate is 2.0-fold (0.30 log units) above it, and the stated range covers the measured number.
By their numbers in this assay, from the lowest: compounds 2 and 3 (each within the scatter of the next); then compound 1.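

In this assay, hydrogen in place of ethyl on a saturated chain carbon, ten or more bonds along the chain from a sulfonyl sulfur, gives a 1.1-fold higher number from compound 2 to compound 3 (0.03 log units; within the scatter), so this change at this position leaves the number within the scatter. Within the data shown here, it is the first step to read this position alone, since compound 1 differs from compound 2 in more than one place. The data offer no explanation for this result. Going by these compounds, whether a longer chain, an amine or a carboxylic acid at this position would keep the number remains open, as does how far the chain can be shortened before the number moves.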